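This account rests on a few compounds, and the source may have more. Where it says the series, first, only, none or still open, it means among the compounds named here.

Measured compounds:
compound 1 `CCc1cc(C)oc(=O)c1`; in a functional assay on A2780 cells (Homo sapiens) for inhibition (a lower number here means a stronger inhibitor, a higher number a weaker inhibitor), compound 1 gives > 50000 nM, a limit of the assay.
compound 2 `C#Cc1cc(C)oc(=O)c1`; in this assay compound 2 gives 3100 nM.
compound 3 `CCCCc1cc(C)oc(=O)c1`; in this assay compound 3 gives > 50000 nM, a limit of the assay.

Compound 3 thus stands at the limit of > 50000 nM in this assay, at which 2 of the 3 values shown sit; no number is known for it, only that it lies past that limit. Of the two steps onto compound 3, one is a step that the two limits leave unreadable from compound 1 to compound 3, since both ends sit at the limit, and the other is an at least 16-fold higher number from compound 2 to compound 3 (1.20 log units; beyond the scatter), a large rise. The remaining measured step, an at least 16-fold lower number from compound 1 to compound 2 (1.20 log units; beyond the scatter), is a large fall and concerns the aromatic carbon, not the chain.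

Compound 4 `CCOCCc1cc(C)oc(=O)c1` differs from compound 3 by ethoxy in place of ethyl on a saturated chain carbon, two bonds along the chain from an aromatic carbon. For the measured compounds named here, no measured step swaps a carbon for an oxygen anywhere on the shared core, and the only step at this place, a step that the two limits leave unreadable from compound 1 to compound 3, gives no readable size. The data therefore offer no direction for this change; with compound 3 at the limit, the plain expectation is that compound 4 also stays near or past it. Compound 4 is expected to give about 50000 nM in this assay, with a range from 15000 nM to 200000 nM. The expected step is a number no higher from compound 3 to compound 4 (the limit leaves the size open), none beyond the scatter.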

Compound 4, half-maximal inhibitory concentration: > 50000 nM
Compound 4: no number, only a limit; the forecaster's own chance of this, stated with the estimate: 70%; the middle value lies on the limit itself.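

In this assay compound 4 gives > 50000 nM, a limit of the assay. No new step can be read between compound 4 and either compound 1 or compound 3, since all three sit at the same limit: the limit of > 50000 nM in this assay, at which 3 of the 4 values shown sit.

The compounds shown leave open how far each of these three lies past that limit, and whether ethoxy in place of ethyl changes the value at all.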